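Benzyloxy in place of fluoroethoxy on a weaker scaffold

This account rests on a few compounds, and the source may have more. Where it says the series, first, only, none or still open, it means among the compounds named here.

Measured so far:
compound 1, `c1ccc(COc2cccc(-c3cn([C@@H]4CN5CCC4CC5)nn3)c2)cc1`, gives 414 nM in an assay on HEK293 cells for displacement of a labelled ligand from Neuronal acetylcholine receptor; alpha4/beta2 (Homo sapiens), read by scintillation counting, with a stated time of 120 min; on this read-out higher numbers stand for weaker inhibition and lower numbers for stronger inhibition;
compound 2, `Fc1ccc(-c2cn([C@@H]3CN4CCC3CC4)nn2)cc1`, gives 515 nM in this assay;
compound 3, `FCCOc1cccc(-c2cn([C@H]3CN4CCC3CC4)nn2)c1`, gives 7050 nM in this assay.

Compound 3 stands at the highest of the three numbers, well apart from both compound 2 and compound 1, and beyond the usual scatter in each case. Compound 4, `c1ccc(COc2cccc(-c3cn([C@H]4CN5CCC4CC5)nn3)c2)cc1`, is compound 3 with one change: phenyl in place of fluoromethyl on a saturated chain carbon bound to an oxygen on an aromatic ring. Among the measured compounds shown here, no two measured compounds differ by exactly this change, so the size of the step is open. Compound 4 is expected to sit somewhat lower than compound 3, with a step of a 2.4-fold lower number from compound 3 to compound 4 (0.37 log units; beyond the scatter) in this assay. The estimate for compound 4 is 3000 nM, with a range from 800 nM to 12000 nM.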

Compound 4, inhibition constant: 5060 nM
Estimate against measurement, compound 4: 1.7-fold (0.23 log units) below; the range from low to high includes it.
By their numbers in this assay, from the lowest: compounds 1 and 2 (each within the scatter of the next); then compounds 4 and 3 (each within the scatter of the next).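

Replacing 2-fluoroethoxy with benzyloxy on the R form gives a 1.4-fold lower number from compound 3 to compound 4 (0.14 log units; within the scatter), so at this position fluoromethyl and phenyl cannot be told apart in this binding measurement. The stereocentre at the saturated ring carbon carries a much larger step: with the same atoms and bonds, going from S to R gives a 12-fold higher number from compound 1 to compound 4 (1.09 log units; beyond the scatter). This comparison comes with a caveat: the fact that one of compounds 1 and 4 is drawn with a defined configuration and the other without, at the place where they differ

Still open, from the compounds shown here alone, is whether an amine on this chain would move the number, and whether 2-fluoroethoxy on the S form would match benzyloxy there.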